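A Methyl Added to the Core: Effect on Cytotoxicity

The compounds below may be only part of what the source reports. "The series", "measured", "known", "first", "only" and "open" are said of these compounds alone.

Of the compounds shown here, three have been measured in an ADME assay on MT4 cells (Homo sapiens) for cytotoxicity, read by MTT assay, with a stated time of 5 days; a lower number here means that less compound is tolerated, a higher number that more compound is tolerated. Compound 1 `COc1ccc(C(=O)c2ccccc2)c(Oc2ccnc(Nc3ccc(C#N)cc3)n2)c1` gives 760 nM in this assay. Compound 2 `COCCc1ccc(Oc2ccnc(Nc3ccc(C#N)cc3)n2)cc1` gives 93300 nM, and compound 3 `COCCc1ccc(Oc2cc(C)nc(Nc3ccc(C#N)cc3)n2)cc1` gives 13800 nM. Compound 1 therefore has the lowest number of the three; its nearest neighbour is compound 3 and its furthest is compound 2. The difference between the core of compound 1 and that of compound 2 is not broken down here.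

Compounds 2 and 3 differ in one place (methyl in place of hydrogen on an aromatic carbon), and in this assay that change gave a 6.8-fold lower number from compound 2 to compound 3 (0.83 log units; beyond the scatter).

Compound 4 `COc1ccc(C(=O)c2ccccc2)c(Oc2nc(Nc3ccc(C#N)cc3)ncc2C)c1` has not yet been measured. It differs from compound 1 in one place (methyl in place of hydrogen on an aromatic carbon). This is the same kind of change as from compound 2 to compound 3, but not the same: in compound 3 the methyl sits next to the ring nitrogen, meta to the (4-cyanophenyl)amino group, meta to a large group and opposite the ring nitrogen, whereas in compound 4 it sits ortho to a large group, two atoms from the ring nitrogen and para to the (4-cyanophenyl)amino group.

Resting on the step from compound 2 to compound 3 (a 6.8-fold lower number from compound 2 to compound 3 (0.83 log units; beyond the scatter)), compound 4 is expected to show a lower number than compound 1, with an estimated step of a 2.2-fold lower number from compound 1 to compound 4 (0.34 log units; beyond the scatter). Compound 4 is estimated at 350 nM in this assay, expected to lie between 100 nM and 1500 nM.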

Compound 4, half-maximal cytotoxic concentration: 7420 nM
For compound 4 the middle estimate is 21-fold (1.33 log units) below the measured one; the measured number lies above the stated range.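

In this assay, placing a methyl in place of hydrogen on an aromatic carbon of the shared core gave a 9.8-fold higher number from compound 1 to compound 4 (0.99 log units; beyond the scatter), so this change moved the number upward here, whereas the earlier step had moved it downward. The same kind of change therefore did not carry over from one core to the other, and the two results differ in direction as well as in number: the same change on two cores in this assay, a 6.8-fold lower number (0.83 log units; beyond the scatter) from compound 2 to compound 3 and a 9.8-fold higher number (0.99 log units; beyond the scatter) from compound 1 to compound 4, 66-fold (1.82 log units) apart, beyond the scatter of two such steps What this does not show is why the two steps part, since the methyl stands in a different place in each pair and the rest of the molecule differs as well, so these two pairs cannot separate the effect of the place from that of the core, and two steps give no rule for the series.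

From the compounds shown here alone, it remains open whether a methyl at one fixed place would give steps of the same direction on both cores. Going by these compounds, it also remains open whether an ethyl group or a chlorine atom on the same aromatic carbon would move the number in this assay as the methyl does.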